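A few compounds are considered here, and "the series" means these few. Any claim that something is new, unique, unknown or untested is made for them only; others in the source may bear on it.

Two analogues of the shared core carry a measured value. Compound 1 `C/C(=N\CC(C)C)c1c(O)c2ccccc2oc1=O` is measured in an assay on isolated protein for inhibition of myosin-2 (Bos taurus), read by spectrophotometry, with a stated time of 24 min (a higher number here means a weaker inhibitor, a lower number a stronger inhibitor), and gives 34000 nM. Compound 2 `C/C(=N\Cc1ccccc1)c1c(O)c2ccccc2[nH]c1=O` reaches only a limit of this assay, >= 100000 nM, so no number is known for it. That limit is the mark (the limit of >= 100000 nM in this assay, at which 1 of the 2 values shown sits). Among the measured compounds shown here, no step between measured compounds is computed here, as compound 1 and compound 2 differ in more than one place. Compound 3 `CCCCC/N=C(\C)c1c(O)c2ccccc2[nH]c1=O` is not yet measured. It differs from compound 2 by butyl in place of phenyl on a saturated chain carbon bound to a double-bonded nitrogen; cut one bond further out, the same difference reads benzyl to pentyl. Starting from a limit for compound 2, the step of an at least 1.2-fold lower number from compound 2 to compound 3 (0.09 log units; that floor lies within the scatter) is expected to be small, within the scatter or a modest gain, and a second limit for compound 3 is a real possibility. Compound 3 is expected to give 80000 nM, within 30000 nM to 200000 nM.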

Compound 3, half-maximal inhibitory concentration: >= 100000 nM
Compound 3: no number, only a limit; the forecaster's own chance of this, stated with the estimate: 55%; middle value at least 1.2-fold (0.09 log units) away from the limit.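

Compound 3 reaches only a limit in this assay, >= 100000 nM. Among the compounds shown here, compound 2 also stands at a limit, so no step from it to compound 3 can be read. The compounds shown leave open whether benzyl and pentyl differ in inhibition at all.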